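A few compounds are considered here, and "the series" means these few. Any claim that something is new, unique, unknown or untested is made for them only; others in the source may bear on it.

In a functional assay on L1210 cells (Mus musculus) for inhibition (a lower number here means a stronger inhibitor, a higher number a weaker inhibitor), compound 1 `O=C1CCCCC/C1=C\c1ccccc1` gives 261000 nM. Compound 2 `O=C1CCCCC/C1=C\c1cccc(Cl)c1`, which has chloro in place of hydrogen on an aromatic carbon, gives 144000 nM. These two values lie within the scatter of each other, so the data do not separate compound 2 from compound 1.

Compound 3 `Cc1cccc(/C=C2\CCCCCC2=O)c1` keeps the shared core and exchanges one group of compound 2: methyl in place of chloro on an aromatic carbon. In words, this is methyl in place of chloro on an aromatic carbon, meta to a group of 9 heavy atoms. Compound 3 has not yet been measured in this assay.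

Within the data shown here, only one measured step bears on this change, and it also concerns a single group on an aromatic carbon: a 1.8-fold lower number from compound 1 to compound 2 (0.26 log units; within the scatter). Among the measured compounds shown here, with only this step as a guide, and with its size inside the scatter, no step beyond the scatter is expected in this assay, in either direction.

The estimated value for compound 3 is 175000 nM, with an expected range from 95000 nM to 320000 nM. This estimate corresponds to an expected 1.2-fold higher number from compound 2 to compound 3 (0.08 log units; within the scatter).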

Compound 3, half-maximal inhibitory concentration: 263000 nM
Compound 3: the middle estimate sits 1.5-fold (0.18 log units) below what was measured; measured number inside the range.
By their numbers in this assay, from the lowest: compounds 2, 1 and 3 (each within the scatter of the next).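

In this assay, this spot on the aromatic ring has now held hydrogen, chloro and methyl, and the three cannot be told apart. Methyl in place of chloro gives a 1.8-fold higher number from compound 2 to compound 3 (0.26 log units; within the scatter) and methyl in place of hydrogen gives a 1.0-fold higher number from compound 1 to compound 3 (0.00 log units; within the scatter) in this series. The earlier pair showed only that chloro could not be separated from hydrogen, whereas this result adds a second single-atom group, carbon rather than chlorine, that also stays inside the scatter, so swaps of this kind at this position have so far produced no real difference in inhibition. Nothing measured here offers a reason why these three compounds read alike.

The compounds shown leave open whether a group with more atoms or a different make-up, such as an amine, a carboxylic acid or a longer chain, would move the number beyond the scatter at this position. They also leave open whether chloro or methyl would read the same at other places on the ring, since all of the substituted compounds shown carry their group at this one position.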